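The compounds below may be only part of what the source reports. "The series", "measured", "known", "first", "only" and "open" are said of these compounds alone.

Working notes on the series.

Compound 1 `O=C(O)CC1CC(CNC(=O)CCCNc2ccccn2)=CCc2ccccc21` gives 2 nM in a functional assay on IGROV-1 cells (Homo sapiens) for inhibition; a higher number here means a weaker inhibitor, a lower number a stronger inhibitor. Compound 2 `O=C(O)CC1CC(CNC(=O)CCCCNc2ccccn2)=CCc2ccccc21` gives 12 nM. Compound 3 `O=C(O)CC1CC(CNC(=O)CCCNC2=NCCN2)=CCc2ccccc21` gives 18 nM, the highest number of the three: the step of a 9.0-fold higher number from compound 1 to compound 3 (0.95 log units; beyond the scatter) lies beyond the scatter, whereas the step of a 1.5-fold higher number from compound 2 to compound 3 (0.18 log units; within the scatter) stays within it. Compound 4 `O=C(O)CC1CC(CNC(=O)CCCc2ccc3c(n2)NCCC3)=CCc2ccccc21` is not yet measured. The change from compound 3 is a group of 10 heavy atoms (8 carbon, 2 nitrogen; one six-membered non-aromatic ring with 1 hetero atom, one six-membered aromatic ring with 1 hetero atom) in place of a group of 6 heavy atoms (3 carbon, 3 nitrogen; one five-membered non-aromatic ring with 2 hetero atoms), on a saturated chain carbon, three bonds along the chain from a carbonyl carbon. For the measured compounds named here, two measured steps bear on this. The step of a 9.0-fold higher number from compound 1 to compound 3 (0.95 log units; beyond the scatter) shows that a five-membered non-aromatic ring with two hetero atoms in place of a six-membered aromatic ring with one hetero atom raised the number, and the step of a 1.5-fold higher number from compound 2 to compound 3 (0.18 log units; within the scatter) shows no shift beyond the scatter when the larger aromatic group on the chain carbon was exchanged. Compound 4 brings a six-membered aromatic ring with one hetero atom back onto that chain carbon, so for compound 4 a step of a 3.6-fold lower number from compound 3 to compound 4 (0.56 log units; beyond the scatter) toward a lower number is expected, of modest size because of a 9.0-fold higher number from compound 1 to compound 3 (0.95 log units; beyond the scatter). The estimate for compound 4 is 5 nM, with a range from 1.5 nM to 20 nM.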

Compound 4, half-maximal inhibitory concentration: 6.9 nM
Compound 4: the middle estimate sits 1.4-fold (0.14 log units) below what was measured, and the stated range covers the measured number.
By their numbers in this assay, from the lowest: compound 1; then compounds 4, 2 and 3 (each within the scatter of the next, the first and the last beyond it).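

In this assay, the group with one six-membered non-aromatic ring and one six-membered aromatic ring, placed on a saturated chain carbon, three bonds along the chain from a carbonyl carbon, improves on the five-membered non-aromatic ring of the comparison compound (a 2.6-fold lower number from compound 3 to compound 4 (0.42 log units; beyond the scatter)). The same group cannot be told apart from the ((pyridin-2-yl)amino)methyl arrangement (a 1.7-fold lower number from compound 2 to compound 4 (0.24 log units; within the scatter)), but it does not match the (pyridin-2-yl)amino arrangement (a 3.5-fold higher number from compound 1 to compound 4 (0.54 log units; beyond the scatter)), so compound 1 keeps the lowest number of the series. Nothing available on these compounds offers an explanation for these differences.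

The compounds shown leave open whether a methyl group on the six-membered aromatic ring of compound 4 would bring its number closer to that of compound 1. They also leave open how an ester in place of the carboxylic acid would affect this assay's read-out.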